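Shrinking the Ring on the Shared Core

This account rests on a few compounds, and the source may have more. Where it says the series, first, only, none or still open, it means among the compounds named here.

Compound 3 `Nc1nc(NC2CCCCC2)c2ncn(/C=C3/CC3(CO)CO)c2n1` has no result in an ADME assay on MOLT-3 cells (Homo sapiens) for cytotoxicity, with a stated time of 7 days; on this read-out lower numbers stand for higher toxicity in this test and higher numbers for lower toxicity in this test: its entry reads "not determined" (no result reported). Its neighbours on the shared core fare alike. Compound 1 `CCCCCCCCOc1nc(N)nc2c1ncn2/C=C1/CC1(CO)CO` reaches only a limit of this assay, > 20000 nM. Compound 2 `CCCCSc1nc(N)nc2c1ncn2/C=C1/CC1(CO)CO` likewise reaches only a limit, > 20000 nM. The step that the two limits leave unreadable from compound 1 to compound 2 therefore cannot be read, and the only thing the measured set shows is the limit of > 20000 nM in this assay, at which 2 of the 3 values shown sit. Compound 4 `Nc1nc(NC2CC2)c2ncn(/C=C3/CC3(CO)CO)c2n1` differs from compound 3 by cyclopropyl in place of cyclohexyl on a nitrogen on an aromatic ring. Among the measured compounds shown here, no measured step bears on this change, so no direction can be taken from the data; what is expected is another value at or near the limit. For compound 4 the estimate in this assay is 20000 nM, between 6000 nM and 60000 nM.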

Compound 4, half-maximal cytotoxic concentration: > 20000 nM
Compound 4 was reported as a limit (the forecaster's own chance of this, stated with the estimate: 80%); the middle value lies on the limit itself.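

In this assay, among the compounds shown here, compound 4 gives only a limit, as do compound 1 and compound 2, so no step among them can be read. As far as these compounds go, whether any of these changes on the shared core alters toxicity remains open.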